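From heptyl to 2-methoxyethynyl on a shared core

The compounds below may be only part of what the source reports. "The series", "measured", "known", "first", "only" and "open" are said of these compounds alone.

- compound 1 `CCCCCCC[C@H]1O[C@@H]2OC(=O)N(C(=O)CCl)[C@@H]2CC1=O`: 96000 nM
- compound 2 `CCCCCCC[C@@]1(C)O[C@@H]2OC(=O)N(C(=O)CCl)[C@@H]2CC1=O`: 28000 nM
- compound 3 `CCCCCC#C[C@]1(C)O[C@@H]2OC(=O)N(C(=O)CCl)[C@@H]2CC1=O`: 32000 nM

All three compounds were tested in a functional assay on L1210 cells (Mus musculus) for inhibition; a higher number here means a weaker inhibitor, a lower number a stronger inhibitor. Compound 2 shares the low end of these numbers with compound 3, and the two lie within the scatter of each other. Compound 1 has a higher number than compound 2, and that gap lies beyond the scatter.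

The next compound to be measured is compound 4 `COC#C[C@@]1(C)O[C@@H]2OC(=O)N(C(=O)CCl)[C@@H]2CC1=O`, which carries 2-methoxyethynyl in place of heptyl on a saturated ring carbon. Compound 3 also carries a triple bond outside aromatic rings and shows 32000 nM, so that feature alone gives no ground to expect a weaker result. For the measured compounds named here, no measured compound carries 2-methoxyethynyl, however, so the outcome remains uncertain. In this assay, a modest rise in the number is expected, near the edge of the scatter. The expected change is a 2.1-fold higher number from compound 2 to compound 4 (0.33 log units; beyond the scatter). For compound 4, the estimated value is 60000 nM, within an expected range of 22000 nM to 160000 nM.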

Compound 4, half-maximal inhibitory concentration: 74000 nM
Compound 4: middle estimate off by 1.2-fold (0.09 log units), on the low side, within the range that was stated.
By their numbers in this assay, from the lowest: compounds 2 and 3 (each within the scatter of the next); then compounds 4 and 1 (each within the scatter of the next).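

This is the first step among the compounds shown that changes only one place, the saturated ring carbon next to the ring oxygen: in this assay the exchange of heptyl for 2-methoxyethynyl gives a 2.6-fold higher number from compound 2 to compound 4 (0.42 log units; beyond the scatter). The result shows that the number responds to what this carbon carries, though only modestly, even though the entering group has fewer heavy atoms and adds a triple bond and a hydrogen-bond acceptor that heptyl lacks. Nothing available accounts for the size of this step.

The exchange alters chain size, the triple bond and the oxygen all at once, so the compounds shown do not separate their contributions. On these data alone, a propyl or a 2-methoxyethyl group on this carbon would bear on that question, and whether either would sit nearer compound 2 or compound 4 remains open.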